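This account rests on a few compounds, and the source may have more. Where it says the series, first, only, none or still open, it means among the compounds named here.

Measured compounds in a functional assay on HeLa cells (Homo sapiens) for inhibition, read by trypan blue exclusion, with a stated time of 72 h; on this read-out higher numbers stand for weaker inhibition of growth and lower numbers for stronger inhibition of growth:
- compound 1 `CC/C(=C(/c1ccc(NC(=O)C(C)C)cc1)c1ccc(OC)cc1)c1ccc(O)cc1` — 5800 nM
- compound 2 `CC/C(=C(\c1ccc(NC(=O)C(C)C)cc1)c1ccc(OC)cc1)c1ccccc1` — 10100 nM
- compound 3 `CC/C(=C(\c1ccc(NC(=O)C(C)C)cc1)c1ccc(OC)cc1)c1ccc(OCc2ccccc2)cc1` — > 30000 nM

Compound 3 stands at a limit of this assay and not at a number; its value is > 30000 nM, and the limit of > 30000 nM in this assay, at which 1 of the 3 values shown sits, shows how many of the measured values sit there. Among the measured compounds shown here, compound 2, the hydrogen analogue, gives 10100 nM in this assay, and the step of an at least 2.9-fold higher number from compound 2 to compound 3 (0.47 log units; beyond the scatter) is the only measured step that bears on the change considered here.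

Compound 4 `CC/C(=C(\c1ccc(NC(=O)C(C)C)cc1)c1ccc(OC)cc1)c1ccc(O)cc1` is not yet measured. It differs from compound 3 by hydrogen in place of benzyl on an oxygen on an aromatic ring, that is, benzyloxy to hydroxy. The step from compound 2 to compound 3 shows the benzyloxy group costing growth inhibition, so its removal is expected to move the number the other way. Compound 1, which also carries a hydroxy group, gives 5800 nM in this assay, and compound 2 gives 10100 nM, both well inside the measurable range.

Compound 4 is therefore expected to come off the limit with a step of about an at least 4.2-fold lower number from compound 3 to compound 4 (0.63 log units; beyond the scatter). The estimate for compound 4 in this assay is 7000 nM, with a range from 2500 nM to 20000 nM.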

Compound 4, concentration for 50% growth inhibition: 3700 nM
Beside the measured number, compound 4's estimate is 1.9-fold (0.28 log units) above it; the range from low to high includes it.
By their numbers in this assay, from the lowest: compounds 4, 1 and 2 (each within the scatter of the next, the first and the last beyond it). At a limit, above all of these: compound 3.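

In this assay, hydrogen in place of benzyl on the oxygen gives an at least 8.1-fold lower number from compound 3 to compound 4 (0.90 log units; beyond the scatter), a step read against a limit and not a number for compound 3: the limit of > 30000 nM in this assay, at which 1 of the 4 values shown sits.

Hydroxy in place of hydrogen on the aromatic carbon also counts on its own, with a 2.7-fold lower number from compound 2 to compound 4 (0.44 log units; beyond the scatter), so the three groups at this place order as hydroxy, hydrogen, benzyloxy, with stronger inhibition of growth first. The configuration of the double bond shows no difference beyond the scatter for the hydroxy pair, with a 1.6-fold lower number from compound 1 to compound 4 (0.20 log units; within the scatter): the fact that compounds 1 and 4 differ only in the configuration as drawn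

On these data alone, whether an amine or a carboxylic acid on this aromatic carbon would match hydroxy stays open. Also open, as far as these compounds go, are how far compound 3 lies past its limit and whether the configuration matters as little with other groups at this place.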